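The source may report more compounds than this note shows. Statements on the series, on what has been measured and on what is new or still open speak of the compounds shown alone.

In a functional assay on SW480 cells (Homo sapiens) for antiproliferative activity, read by MTT assay, with a stated time of 48 h (on this read-out higher numbers stand for weaker inhibition and lower numbers for stronger inhibition), three compounds on a shared core have been measured: compound 1 `CC(CCO)n1cnc2c(Cl)nc(F)nc21` gives a value of 16800 nM and compound 2 `CCCCC(CCO)n1cnc2c(Cl)nc(F)nc21` gives 13200 nM. Compound 3 `CCCCCCC(CCO)n1cnc2c(Cl)nc(F)nc21`, with 12900 nM, stands within the scatter of both others, so the three cannot be ranked. Compound 4 `CC(C)(C)[Si](C)(C)OCC(CCO)n1cnc2c(Cl)nc(F)nc21`, not yet measured, differs from compound 3 on a saturated chain carbon, two bonds along the chain from an aromatic nitrogen: a group of 8 heavy atoms (6 carbon, 1 oxygen, 1 silicon; no ring) in place of a group of 5 heavy atoms (5 carbon; no ring), on a saturated chain carbon, two bonds along the chain from an aromatic nitrogen. Two measured steps changed the group at that same place (a 1.3-fold lower number from compound 1 to compound 2 (0.10 log units; within the scatter); a 1.3-fold lower number from compound 1 to compound 3 (0.11 log units; within the scatter)), and both stayed within the scatter, as did the further chain extension (a 1.0-fold lower number from compound 2 to compound 3 (0.01 log units; within the scatter)). None of these compounds carries oxygen or silicon in that group, so the evidence is indirect and the range must stay wide. On these small steps, no change beyond the scatter is expected in this assay, and the expected step is small (a 1.2-fold lower number from compound 3 to compound 4 (0.07 log units; within the scatter)). Compound 4 is expected at an estimated 11000 nM (5000 nM to 22000 nM).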

Compound 4, half-maximal inhibitory concentration: 8020 nM
Compound 4: the middle estimate sits 1.4-fold (0.14 log units) above what was measured, and the stated range covers the measured number.
By their numbers in this assay, from the lowest: compounds 4, 3, 2 and 1 (each within the scatter of the next, the first and the last beyond it).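

At this place, on a saturated chain carbon, two bonds along the chain from an aromatic nitrogen, a group holding oxygen and silicon behaves in this assay much like the plain alkyl chains: a 1.6-fold lower number from compound 3 to compound 4 (0.21 log units; within the scatter) and a 1.6-fold lower number from compound 2 to compound 4 (0.22 log units; within the scatter) do not separate it from pentyl or propyl. Against the hydrogen atom of compound 1, however, it gives the first step at this place to pass the scatter, a 2.1-fold lower number from compound 1 to compound 4 (0.32 log units; beyond the scatter), and that step is only modest. No accompanying measurement bears on this result.

Which part of the entering group goes with that step, its oxygen or its silicon, remains open. So does whether a hydroxymethyl group, an aminomethyl group or a benzyl ether at this place would give a larger step from compound 1.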